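This account rests on a few compounds, and the source may have more. Where it says the series, first, only, none or still open, it means among the compounds named here.

Compounds measured in a functional assay on PC-3 cells (Homo sapiens) for cytotoxicity, read by MTT assay, with a stated time of 48 h; on this read-out lower numbers stand for stronger inhibition and higher numbers for weaker inhibition:
- compound 1 `COc1cc(-n2c(-c3ccccc3)cn(C(C)=O)c2=O)cc(OC)c1OC`, for which the assay gives > 50000 nM
- compound 2 `COc1cc(-n2c(-c3ccc(Br)cc3)cn(C(C)=O)c2=O)cc(OC)c1OC`, which gives 3100 nM
- compound 3 `COc1cc(-n2c(-c3ccc(Cl)cc3)cn(C(C)=O)c2=O)cc(OC)c1OC`, recorded as "not determined" (no result reported)

The value of compound 1 is a limit of the assay, not a number, and it is the limit of > 50000 nM in this assay, at which 1 of the 3 values shown sits. Compound 2 gives 3100 nM in this assay, and the change from hydrogen to bromo on an aromatic carbon yields an at least 16-fold lower number from compound 1 to compound 2 (1.20 log units; beyond the scatter). Compound 3 has no number in this assay, so it cannot be placed among the measured values; it differs from compound 2 only in carrying chloro where compound 2 carries bromo.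

Compound 4 `COc1cc(-n2c(-c3ccc([N+](=O)[O-])cc3)cn(C(C)=O)c2=O)cc(OC)c1OC` has not been measured. Its difference from compound 3 is nitro in place of chloro on an aromatic carbon. Going by the values given here, no measured step exchanges one group for another at this position; the only step known, from compound 1 to compound 2, shows that putting a group on this aromatic carbon can move the number a great deal, but says nothing about nitro against chloro. Compound 4 is therefore expected to give about 6000 nM in this assay, with a wide range from 800 nM to 50000 nM.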

Compound 4, half-maximal inhibitory concentration: 32900 nM
Compound 4: middle estimate off by 5.5-fold (0.74 log units), on the low side; low and high end bracket the measured number.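

With compound 4, this aromatic carbon gains its first measured exchange of one group for another, and the result in this assay is an 11-fold higher number from compound 2 to compound 4 (1.03 log units; beyond the scatter), so the lower number seen with bromo does not carry over to nitro. Set against hydrogen, nitro gives an at least 1.5-fold lower number from compound 1 to compound 4 (0.18 log units; that floor lies within the scatter), so no firm gain over hydrogen can be claimed for it. The value of compound 1 is a limit of the assay, not a number: the limit of > 50000 nM in this assay, at which 1 of the 4 values shown sits.

Steps involving compound 3 cannot be read, since compound 3 has no number, and chloro therefore stays unplaced against both bromo and nitro. Also open, going by these compounds, is how a fluoro group, an amine or a carboxylic acid on this aromatic carbon would compare with bromo.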